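The source may report more compounds than this note shows. Statements on the series, on what has been measured and on what is new or still open speak of the compounds shown alone.

Compound 2 `Cn1cncc1CN1CC(N(CC2CCN(C(=O)Nc3ccc(Br)cc3)CC2)S(=O)(=O)c2ccccn2)Cc2cc(C#N)ccc21` and compound 1 `CCC(=O)N1CCC(CN(C2Cc3cc(C#N)ccc3N(Cc3cncn3C)C2)S(=O)(=O)c2ccccn2)CC1` share the same core and differ only in the group attached to a carbonyl carbon. In an ADME assay on Caco-2 cells (Homo sapiens) for permeability, in the apical to basolateral direction (on this read-out lower numbers stand for lower permeability and higher numbers for higher permeability), compound 2 gives 0.6 10^-6 cm/s, and in this assay compound 1 gives 0.5 10^-6 cm/s; the two numbers lie within the scatter of each other, so neither can be called more or less permeable. Among the compounds with values here, the one step recorded between them is a 1.2-fold higher number from compound 1 to compound 2 (0.08 log units; within the scatter). Compound 3 `CC(C)OC(=O)N1CCC(CN(C2Cc3cc(C#N)ccc3N(Cc3cncn3C)C2)S(=O)(=O)c2ccccn2)CC1` has not yet been measured in this assay; it differs from compound 2 as follows: isopropoxy in place of (4-bromophenyl)amino on a carbonyl carbon This change sits at the same carbonyl carbon as the earlier step. Because a 1.2-fold higher number from compound 1 to compound 2 (0.08 log units; within the scatter) stayed within the scatter, no step beyond the scatter is expected here either, in either direction. Compound 3 is therefore estimated at 0.7 10^-6 cm/s, with a range from 0.3 10^-6 cm/s to 1.6 10^-6 cm/s, which means an expected step of a 1.2-fold higher number from compound 2 to compound 3 (0.07 log units; within the scatter).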

Compound 3, apparent permeability: 1 10^-6 cm/s
Beside the measured number, compound 3's estimate is 1.4-fold (0.15 log units) below it; measured number inside the range.
By their numbers in this assay, from the lowest: compounds 1, 2 and 3 (each within the scatter of the next).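

In this assay, this carbonyl carbon now carries a third kind of group, and the picture from the first pair holds: swapping (4-bromophenyl)amino for isopropoxy gives a 1.7-fold higher number from compound 2 to compound 3 (0.22 log units; within the scatter). This is a larger structural swap than the size of the step suggests, since the aromatic ring and the hydrogen-bond donor leave and the group shrinks from 8 heavy atoms to 4, while isopropoxy in place of ethyl gives a 2.0-fold higher number from compound 1 to compound 3 (0.30 log units; within the scatter). Nothing measured here explains where these numbers fall.

On these data alone, whether any group on this carbonyl carbon can move the number beyond the scatter remains open. A longer chain such as hexyl, or a group carrying an amine or a carboxylic acid, could test this, and the rest of the shared core is equally untested by these compounds.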